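This account rests on a few compounds, and the source may have more. Where it says the series, first, only, none or still open, it means among the compounds named here.

Compound 1 `CC1=CCC[C@H]2[C@](C)(CC3=CC(=O)C=CC3=O)[C@@H](C)CC[C@]12C`: 18100 nM
Compound 2 `CC(C)C[C@H](NC1=CC(=O)C=C(C(C)(C)C)C1=O)C(=O)O`: 57200 nM

These values come from a functional assay on HeLa cells (Homo sapiens) for cytotoxicity, read by MTT assay, with a stated time of 72 h; a higher number here means a weaker inhibitor, a lower number a stronger inhibitor. Compound 1 stands lowest of the two at 18100 nM, making it the stronger inhibitor, and its gap to compound 2 lies beyond the usual scatter. Compound 3 `CC1=CCC[C@H]2[C@](C)(CC3=CC(=O)C=C(N[C@@H](C)C(=O)O)C3=O)[C@@H](C)CC[C@]12C` keeps the core of compound 1 but changes one place: (1-carboxyethyl)amino in place of hydrogen on a double-bonded ring carbon. Among the measured compounds shown here, no measured pair shows this change, so the guess is loose. Compound 2 also carries an amino acid chain and reads 57200 nM, which suggests a small shift toward a higher number in this assay, perhaps none beyond the scatter. The expected change is a 1.5-fold higher number from compound 1 to compound 3 (0.17 log units; within the scatter). Compound 3 is estimated at 27000 nM, with an expected range of 9000 nM to 75000 nM.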

Compound 3, half-maximal inhibitory concentration: 11700 nM
Compound 3: middle estimate off by 2.3-fold (0.36 log units), on the high side; measured number inside the range.
By their numbers in this assay, from the lowest: compounds 3 and 1 (each within the scatter of the next); then compound 2.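

On the core of compound 1, (1-carboxyethyl)amino in place of hydrogen on a double-bonded ring carbon gives a 1.5-fold lower number from compound 1 to compound 3 (0.19 log units; within the scatter) in this assay and so leaves the reading unchanged within the scatter. This position of the shared core therefore carries a group of 6 heavy atoms with a defined stereocentre without a shift beyond the scatter. Nothing here gives a reason for this result. Still open, on these data alone, is whether a plain amine, a longer chain or a carboxylic acid without the nitrogen at this position would read the same. Also open, as far as these compounds go, is whether the mirror-image form of the chain would match compound 3 .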